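Replacing the aminophenyl of compound 1 with a halogenated phenyl

The compounds below may be only part of what the source reports. "The series", "measured", "known", "first", "only" and "open" are said of these compounds alone.

Measured compounds:
compound 1, `CC1(C)Oc2ccc(C#N)cc2[C@@H](/N=C(\NC#N)Nc2ccc(N)cc2)[C@@H]1O`, 3500 nM
compound 2, `COC(=O)c1cn([C@@H]2c3cc(C#N)ccc3OC(C)(C)[C@H]2O)c2ccccc12`, 500 nM

In a functional assay (aorta) with Rattus norvegicus as the target (a lower number here means a stronger inhibitor, a higher number a weaker inhibitor), compound 1 gives 3500 nM, the highest of the two numbers, so it is the weaker inhibitor of the pair. Compound 2, built on a different core, gives 500 nM in this assay, a lower number that lies beyond the usual scatter of the measurement. Compound 3, `CC1(C)Oc2ccc(C#N)cc2[C@@H](/N=C(\NC#N)Nc2ccc(Cl)c(F)c2)[C@@H]1O`, has not yet been measured. It keeps the core of compound 1 and changes only the aromatic group on the amine nitrogen: 4-chloro-3-fluorophenyl in place of 4-aminophenyl on an amine nitrogen. Nothing in the measured pair shows what this change does, so the expectation rests on the structure alone. The two compounds are otherwise identical, and the group that leaves carries a hydrogen-bond donor and acceptor that the entering group lacks. A moderate move toward a stronger inhibitor is expected, a 3.5-fold lower number from compound 1 to compound 3 (0.54 log units; beyond the scatter), rather than no change. Compound 3 is therefore estimated at 1000 nM in this assay, with a range from 300 nM to 3500 nM.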

Compound 3, half-maximal inhibitory concentration: 1660 nM
Compound 3: the middle estimate sits 1.7-fold (0.22 log units) below what was measured, and the stated range covers the measured number.
By their numbers in this assay, from the lowest: compound 2; then compound 3; then compound 1.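

In this assay, the aromatic group on the amine nitrogen now has a measured effect: 4-chloro-3-fluorophenyl in place of 4-aminophenyl gives a 2.1-fold lower number from compound 1 to compound 3 (0.32 log units; beyond the scatter), a modest step. For the compounds shown here, this is the first comparison in which only one place changes, since compound 2 is built on a different core and could not show what this group does. The hydrogen-bond donor and acceptor of 4-aminophenyl are absent from the entering group, yet the number in this assay does not rise, so this position does not depend on them for activity here. No measured evidence explains the step, and the removal of the amino group and the arrival of the two halogens happen together in one change.

On these data alone, it remains open which part of the change carries the step, and whether a plain phenyl, or a phenyl bearing chlorine alone or fluorine alone, would give a number like that of compound 1 or of compound 3. As far as these compounds go, how a methoxy group or a carboxylic acid on this ring would read on the shared core also remains open.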